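The compounds below may be only part of what the source reports. "The series", "measured", "known", "first", "only" and "open" are said of these compounds alone.

In a functional assay on A549 cells (Homo sapiens) for cytotoxicity, read by MTT assay, with a stated time of 72 h (a higher number here means a weaker inhibitor, a lower number a stronger inhibitor), compound 1 `CNC(=O)c1cc(Oc2ccc(C(=O)/C=C/c3cccc(Br)c3)cc2)ccn1` gives 9940 nM, and compound 2 `CNC(=O)c1cc(Oc2ccc(C(=O)/C=C/c3ccc(Cl)c(Cl)c3)cc2)ccn1` gives 33700 nM. Compound 3 `CNC(=O)c1cc(Oc2ccc(C(=O)/C=C/c3ccc(Br)cc3)cc2)ccn1` stands at > 50000 nM, which is a limit of the assay and not a number.

The next change leads to compound 4 `CNC(=O)c1cc(Oc2ccc(C(=O)/C=C/c3ccc([N+](=O)[O-])cc3)cc2)ccn1`: nitro in place of bromo on an aromatic carbon. This places nitro in place of bromo on an aromatic carbon, para to a large group, giving 4-nitrophenyl in place of 4-bromophenyl.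

The measured steps all alter this same aryl group. Two lie beyond the scatter, a 3.4-fold higher number from compound 1 to compound 2 (0.53 log units; beyond the scatter) and an at least 5.0-fold higher number from compound 1 to compound 3 (0.70 log units; beyond the scatter), whereas the floor of an at least 1.4-fold higher number from compound 2 to compound 3 (0.17 log units; that floor lies within the scatter) lies within it. None exchanges bromo for nitro, so they bear on this change only indirectly. The weak reading for compound 3 at > 50000 nM is the nearest guide, and compound 4 is expected to remain weak in this assay, quite possibly at the same limit.

The expected change is an at least 1.2-fold lower number from compound 3 to compound 4 (0.09 log units; that floor lies within the scatter), with no firm direction beyond the scatter. For compound 4 the estimate is 40000 nM, with an expected range of 15000 nM to 80000 nM.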

Compound 4, half-maximal inhibitory concentration: > 50000 nM
Compound 4 ended at the assay's limit (the forecaster's own chance of this, stated with the estimate: 50%); at least 1.2-fold (0.09 log units) between middle value and limit.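

Nitro, like bromo, para to a large group leaves the compound at a limit of the assay and not at a number, so the step between compound 3 and compound 4 cannot be read: the limit of > 50000 nM in this assay, at which 2 of the 4 values shown sit. In this assay the gap to the 3-bromophenyl analogue recurs, with an at least 5.0-fold higher number from compound 1 to compound 4 (0.70 log units; beyond the scatter), and it now holds for both groups tested at this place. The gap to the 3,4-dichlorophenyl analogue remains unresolved, with an at least 1.4-fold higher number from compound 2 to compound 4 (0.17 log units; that floor lies within the scatter).

Still open, from the compounds shown here alone, is whether any group para to a large group can give a measurable value here; an amine or a methoxy group at that place would test this. Going by these compounds, how far compound 3 and compound 4 lie past the limit, and whether they differ at all, also remains unknown.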